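Dropping the chloro group from compound 2

This account rests on a few compounds, and the source may have more. Where it says the series, first, only, none or still open, it means among the compounds named here.

Three close relatives of one core have been tested in a functional assay on the whole organism with Rattus norvegicus as the target, at a dose of 3 mg/kg by the oral route; a lower number here means a weaker effect, a higher number a stronger effect of the compound at the dose given. Compound 1 `COc1ccc(-c2cc(Cl)cc(C(=O)Nc3nn[nH]n3)n2)cc1OC` gives 30% there. Compound 2 `Cc1ccc(-c2cc(Cl)cc(C(=O)Nc3nn[nH]n3)n2)cc1C` gives 32% in this assay, and compound 3 `O=C(Nc1nn[nH]n1)c1cc(Cl)cc(-c2ccc([N+](=O)[O-])cc2)n1` gives 23%. Among these three numbers the one for compound 2 is the largest, yet both compound 1 and compound 3 fall within the usual scatter of it, so nothing separates the three with confidence.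

Compound 4 `Cc1ccc(-c2cccc(C(=O)Nc3nn[nH]n3)n2)cc1C` has not yet been measured in this assay. It differs from compound 2 in one place: hydrogen in place of chloro on an aromatic carbon. Among the measured compounds shown here, no measured pair in this set shows what such a removal does, so there is no step to lean on. Without such guidance the size of the step from compound 2 to compound 4 in this assay is open; a change of either sign, or none beyond the scatter, is possible, and the account leans toward a modest loss. The expected step is a number 7 percentage points lower from compound 2 to compound 4 (within the scatter). For compound 4 the estimated read-out in this assay is 25%, with a range from 10% to 40%.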

Compound 4, a percentage reported as inhibition, in the whole organism at one dose (the size of the read-out at that dose, not a potency): 28%
For compound 4 the middle estimate is 3 percentage points below the measured one; measured number inside the range.
By their numbers in this assay, from the lowest: compounds 3, 4, 1 and 2 (each within the scatter of the next).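

In this assay, among the compounds shown here, the first pair that reads on this position gives a number 4 percentage points lower from compound 2 to compound 4 (within the scatter), so hydrogen in place of chloro, opposite the ring nitrogen, leaves a read-out that cannot be told apart from that of compound 2. The earlier compounds shown here all carried the chloro group and so could say nothing about this position; compound 4 shows that, with the rest of compound 2 kept, the chloro group is not required for an effect of this size at this one dose. Nothing available here offers an explanation for this result.

Only this single replacement is shown at this position, so it remains open whether an amine or a carboxylic acid there would move the read-out beyond the scatter. As far as these compounds go, it also remains open whether removing the chloro group has the same small effect when the other ring carries the nitro group of compound 3 or the two methoxy groups of compound 1.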